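Notes on compound 4: phenyl in place of methoxy

The source may hold more compounds than are shown below. What is called first, only, known or untested is meant among the compounds shown, and "the series" means these compounds.

Values in a functional assay on MT2 cells (Homo sapiens) for antiproliferative activity, read by MTT assay, with a stated time of 72 h; a lower number here means a stronger inhibitor of growth, a higher number a weaker inhibitor of growth:
- compound 1 `O=C(COc1c(-c2ccccc2)oc2ccccc2c1=O)Nc1ccccc1`: 6720 nM
- compound 2 `O=C(COc1c(-c2ccccc2)oc2ccccc2c1=O)Nc1ccc(F)cc1`: > 10000 nM (a limit)
- compound 3 `COc1ccc(NC(=O)COc2c(-c3ccccc3)oc3ccccc3c2=O)cc1`: > 10000 nM (a limit)

Compound 3 is known only as a limit, > 10000 nM. Compound 4 `O=C(COc1c(-c2ccccc2)oc2ccccc2c1=O)Nc1ccc(-c2ccccc2)cc1` differs from compound 3 by phenyl in place of methoxy on an aromatic carbon, para to a large group. Among the measured compounds shown here, three measured steps bear on this: an at least 1.4-fold higher number from compound 1 to compound 2 (0.17 log units; that floor lies within the scatter), an at least 1.4-fold higher number from compound 1 to compound 3 (0.17 log units; that floor lies within the scatter) and a step that the two limits leave unreadable from compound 2 to compound 3. The first two have floors within the scatter, and the third has no readable size. No step beyond the scatter is therefore expected in this assay, and no direction can be assigned. The estimate corresponds to a number no higher from compound 3 to compound 4 (the limit leaves the size open), an expected step only. For compound 4 the estimated value is 10000 nM, with an expected range of 3500 nM to 30000 nM.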

Compound 4, concentration for 50% growth inhibition: > 10000 nM
Compound 4 gave a limit, no number; the forecaster's own chance of this, stated with the estimate: 65%; the middle value sits exactly at the limit.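

In this assay, phenyl on an aromatic carbon, para to a large group, gives an at least 1.4-fold higher number from compound 1 to compound 4 (0.17 log units; that floor lies within the scatter). A substituent carrying a six-membered aromatic ring thus joins fluoro and methoxy at this place, and it too yields no measurable number. The steps among compound 2, compound 3 and compound 4 cannot be read, and the result gives only a shared ceiling: the limit of > 10000 nM in this assay, at which 3 of the 4 values shown sit.

From the compounds shown here alone, whether any of these three groups truly differs from hydrogen stays open. So does whether an amine or a carboxylic acid at this place would return a measurable value.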